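Chloro to Trifluoromethyl Ortho to the Ethoxy Group

The compounds below may be only part of what the source reports. "The series", "measured", "known", "first", "only" and "open" are said of these compounds alone.

Two measured compounds share one core and differ only in the group ortho to the ethoxy group. Compound 1 `CCOc1ccc(-c2cncnc2-c2cc(OC)c(OC)c(OC)c2)cc1F` carries fluoro there, and in a functional assay on SiHa cells (Homo sapiens) for antiproliferative activity, read by CCK-8 assay, with a stated time of 72 h (a higher number here means a weaker inhibitor, a lower number a stronger inhibitor), compound 1 gives 800 nM. Compound 2 `CCOc1ccc(-c2cncnc2-c2cc(OC)c(OC)c(OC)c2)cc1Cl` carries chloro, and in this assay compound 2 gives 150 nM, the lowest of the two numbers seen so far. Within the data shown here, the only step measured is a 5.3-fold lower number from compound 1 to compound 2 (0.73 log units; beyond the scatter), so a larger halogen at this position went with a clearly lower number.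

Compound 3 `CCOc1ccc(-c2cncnc2-c2cc(OC)c(OC)c(OC)c2)cc1C(F)(F)F` has not yet been measured. It differs from compound 2 as follows: trifluoromethyl in place of chloro on an aromatic carbon. Among the measured compounds shown here, the single step that bears on this change is the one from fluoro to chloro, and it was modest. Growing the group further, from chloro to trifluoromethyl, has no direct precedent here, so the expectation for compound 3 in this assay is a step of a 1.4-fold lower number from compound 2 to compound 3 (0.13 log units; within the scatter), at most a small gain and possibly none beyond the scatter. Compound 3 is therefore estimated at 110 nM, with a range from 40 nM to 350 nM.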

Compound 3, half-maximal inhibitory concentration: 20000 nM
Compound 3: middle estimate off by 180-fold (2.26 log units), on the low side, and the stated range ends below it.
By their numbers in this assay, from the lowest: compound 2; then compound 1; then compound 3.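

In this assay the earlier pair showed only a lower number on going from fluoro to chloro, but the further change to trifluoromethyl gives a 130-fold higher number from compound 2 to compound 3 (2.12 log units; beyond the scatter) and so shows that this place, ortho to an ethoxy group, is far from open to every replacement. Trifluoromethyl also falls behind fluoro, with a 25-fold higher number from compound 1 to compound 3 (1.40 log units; beyond the scatter), so across these three compounds the number does not fall steadily as the group changes, and compound 3 goes against the direction set by the step between the two halogens. Nothing at hand accounts for this sharp reversal.

The three compounds leave open whether the large rise belongs to trifluoromethyl alone or would also come with other groups at this place, such as methyl, methoxy, bromo or a nitrile, which would show how narrow the range of accepted groups really is. They also leave open whether trifluoromethyl would cost as much if the ethoxy group gave way to a longer chain or to a simple methoxy group.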